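Trimming the amide of compound 3 to a primary carbamoyl

The source may report more compounds than this note shows. Statements on the series, on what has been measured and on what is new or still open speak of the compounds shown alone.

Of the compounds shown here, three sharing one core have been measured. Compound 1 `CCCNS(=O)(=O)c1ccc(Nc2ncc3c(n2)N(C2CCCC2)[C@H](CC)C(=O)N3C)cc1` gives 2100 nM in a functional assay on NCI-H1975 cells (Homo sapiens) for antiproliferative activity, read by CCK-8 assay, with a stated time of 72 h; a higher number here means a weaker inhibitor of growth, a lower number a stronger inhibitor of growth. Compound 2 `CC[C@@H]1C(=O)N(C)c2cnc(-n3ccc4cc(F)ccc43)nc2N1C1CCCC1` gives 46500 nM, and compound 3 `CC[C@@H]1C(=O)N(C)c2cnc(-n3ccc4cc(C(=O)NC5CCCC5)ccc43)nc2N1C1CCCC1` gives 856 nM. Compound 3 therefore holds the lowest number of the three, set apart from compound 1 by a gap beyond the scatter and from compound 2 by the much larger step a 54-fold lower number from compound 2 to compound 3 (1.73 log units; beyond the scatter), which followed the exchange of fluoro for cyclopentylcarbamoyl on the aromatic carbon.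

Compound 4 `CC[C@@H]1C(=O)N(C)c2cnc(-n3ccc4cc(C(N)=O)ccc43)nc2N1C1CCCC1` is not yet measured. It differs from compound 3 by hydrogen in place of cyclopentyl on an amide-type nitrogen; read one bond further out, cyclopentylcarbamoyl becomes carbamoyl. For the measured compounds named here, no measured step removes the cyclopentyl from this amide, so the only guide is a 54-fold lower number from compound 2 to compound 3 (1.73 log units; beyond the scatter), which shows that the group on this aromatic carbon strongly shapes the number. Compound 4 is expected to keep the carbamoyl but lose the cyclopentyl, so its number is estimated to rise by a 3.3-fold higher number from compound 3 to compound 4 (0.51 log units; beyond the scatter), a moderate step beyond the scatter toward weaker growth inhibition. For compound 4 the expected value is 2800 nM, within the range 800 nM to 9000 nM.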

Compound 4, concentration for 50% growth inhibition: 3380 nM
Beside the measured number, compound 4's estimate is 1.2-fold (0.08 log units) below it; the range from low to high includes it.
By their numbers in this assay, from the lowest: compound 3; then compounds 1 and 4 (each within the scatter of the next); then compound 2.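

For the compounds shown here, the change from fluoro to carbamoyl on this aromatic carbon gives a 14-fold lower number from compound 2 to compound 4 (1.14 log units; beyond the scatter) in this assay, so the amide with no substituent on its nitrogen already stands well apart from fluoro, and the earlier compounds could not show this separately from the cyclopentyl. Hydrogen in place of cyclopentyl on the amide-type nitrogen gives a 3.9-fold higher number from compound 3 to compound 4 (0.60 log units; beyond the scatter), a modest step beyond the scatter and smaller than the step from fluoro, so among compounds 2, 3 and 4 the carbamoyl accounts for the larger part of the gain and the cyclopentyl for a smaller but real part. Nothing available here explains why either change moves the number as it does.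

The compounds shown leave open whether a methyl or ethyl group on that nitrogen would keep the number of compound 3, and whether a longer chain or a cyclohexyl ring would lower it further. They also leave open how a carboxylic acid or a nitrile would compare with carbamoyl on the same aromatic carbon.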